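Epimer of an Iminosugar Tested

The source may report more compounds than this note shows. Statements on the series, on what has been measured and on what is new or still open speak of the compounds shown alone.

Measured so far:
compound 1 `CCC[C@@H]1NC[C@@H](O)[C@@H](O)[C@H](O)[C@H]1O` — 0%
compound 2 `CC[C@H]1NC[C@@H](O)[C@@H](O)[C@H](O)[C@H]1O` — 3.9%

In an assay on isolated protein for inhibition of uncharacterized protein (Sus scrofa), tested at 1000 uM (a higher number here means more inhibition at the concentration tested (going by the name of the read-out), a lower number less inhibition), compound 2 gives 3.9%, which is the higher of the two numbers recorded, while compound 1 gives 0%; the gap between them lies within the scatter, so the two numbers are to be taken as level. Both sit essentially at the floor of what this assay can report.

Compound 3 `CC[C@@H]1NC[C@@H](O)[C@@H](O)[C@H](O)[C@H]1O` has not yet been measured. It relates to compound 2 as follows: the two compounds have the same atoms and bonds and differ only in configuration as drawn: 1 of 5 stereo elements differ; a stereocentre at a saturated ring carbon is drawn R in compound 2 and S in compound 3. Among the compounds with values here, no step between measured compounds is available to gauge what such a change might bring, and with compound 2 at 3.9% there is little room for a downward move.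

Compound 3 is therefore expected to show no step beyond the scatter, an estimated change of a number 0.9 percentage points lower from compound 2 to compound 3 (within the scatter), giving an expected value of 3% with a range from -5% to 14%.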

Compound 3, a percentage reported as inhibition, at one concentration (the size of the read-out at that concentration, not a potency): 0%
Beside the measured number, compound 3's estimate is 3 percentage points above it, and the stated range covers the measured number.
By their numbers in this assay, from the lowest: compounds 1, 3 and 2 (each within the scatter of the next).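

The comparison of compound 2 with compound 3 varies one element only: the fact that compounds 2 and 3 differ only in the configuration as drawn. In this assay, turning the stereocentre at a saturated ring carbon from R to S gives a number 3.9 percentage points lower from compound 2 to compound 3 (within the scatter), so this inversion brings no readable change at this level of inhibition. Hydrogen in place of methyl on a saturated chain carbon, two bonds along the chain from a saturated ring carbon, gives no change at the digits printed from compound 1 to compound 3 (within the scatter), so this shortening of the chain also moves nothing beyond the scatter.

All three compounds lie so close to the floor of the assay that neither change can be said to matter or not in a compound with real inhibition. On these data alone, whether a longer chain, or an amine or a carboxylic acid at the end of the chain, would lift the read-out remains open.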